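The compounds below may be only part of what the source reports. "The series", "measured", "known", "first", "only" and "open" are said of these compounds alone.

Measured compounds in a functional assay on MCF7 cells (Homo sapiens) for cytotoxicity, read by sulforhodamine B assay, with a stated time of 48 h; a higher number here means that more compound is tolerated, a lower number that less compound is tolerated:

Compound 1, `COc1ccc(/C(Cl)=C/C=C(\C#N)C(=O)c2c(C)[nH]c3ccccc23)cc1`: compound 1 gives > 100000 nM, a limit of the assay.
Compound 2, `COc1ccc(/C(Cl)=C/C=C(\C#N)C(=O)c2c[nH]c3ccccc23)cc1`: compound 2 gives > 100000 nM, also a limit.
Compound 3, `COc1ccc(/C(Cl)=C/C=C(\C#N)C(=O)c2c[nH]c3ccccc23)cc1OC`: compound 3 gives > 100000 nM, again a limit.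

Compound 3 thus stands at the limit shared by every value shown so far (the limit of > 100000 nM in this assay, at which 3 of the 3 values shown sit). Compound 4, `COc1ccc(/C(Cl)=C/C=C(\C#N)C(=O)c2c(C)[nH]c3ccccc23)cc1OC`, differs from compound 3 by methyl in place of hydrogen on an aromatic carbon. Among the compounds with values here, the steps that bear on it are a step that the two limits leave unreadable from compound 1 to compound 2, the same change run backwards, and a step that the two limits leave unreadable from compound 2 to compound 3; both are left unreadable by the limits on either side, so no size can be drawn from them. The expectation is therefore that the step of a number no higher from compound 3 to compound 4 (the limit leaves the size open) stays within the scatter and that compound 4 again reports a limit. Compound 4 is estimated at 100000 nM, with a range from 30000 nM to 300000 nM.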

Compound 4, concentration lethal to 50% of the cells: > 100000 nM
Compound 4 was reported as a limit (the forecaster's own chance of this, stated with the estimate: 85%); the middle value sits exactly at the limit.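

No step to compound 4 from compound 3 or compound 1 can be read, because all four compounds report the same limit: the limit of > 100000 nM in this assay, at which 4 of the 4 values shown sit.

The compounds shown leave open whether methyl or methoxy in place of hydrogen changes cytotoxicity at all.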